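A few compounds are considered here, and "the series" means these few. Any claim that something is new, unique, unknown or untested is made for them only; others in the source may bear on it.

Compound 3 `Nc1ccccc1NC(=O)c1ccc(CSC(=S)N2CCN(c3ncccn3)CC2)cc1` stands lowest of the three measured compounds in a functional assay on MGC-803 cells (Homo sapiens) for antiproliferative activity, read by CCK-8 assay, with a stated time of 72 h, tested at 8 uM (a higher number here means a stronger effect of the compound at the concentration tested, a lower number a weaker effect), giving 64.8%. Compound 1 `Nc1ccccc1NC(=O)c1ccc(CSC(=S)N2CCN(Cc3ccccn3)CC2)cc1` gives 65.2%, and the step of a number 0.4 percentage points lower from compound 1 to compound 3 (within the scatter) is within the scatter, so the two are not ordered. Compound 2 `Nc1ccccc1NC(=O)c1ccc(CSC(=S)N2CCN(Cc3ccncc3)CC2)cc1` gives 79.3%, and the step of a number 14.5 percentage points lower from compound 2 to compound 3 (beyond the scatter) is beyond the scatter. Compound 4 `Nc1ccccc1NC(=O)c1ccc(CSC(=S)N2CCN(c3ccccc3F)CC2)cc1` differs from compound 3 by 2-fluorophenyl in place of pyrimidin-2-yl on an amine nitrogen in a ring. Among the compounds with values here, no measured step exchanges the pyrimidin-2-yl for a carbon-only ring; the steps that touch this ring nitrogen, a number 0.4 percentage points lower from compound 1 to compound 3 (within the scatter) and a number 14.5 percentage points lower from compound 2 to compound 3 (beyond the scatter), are small or modest. Any step in this assay is therefore expected to be within the scatter, a number 1.2 percentage points higher from compound 3 to compound 4 (within the scatter). Compound 4 is estimated at 66%, with a range from 50% to 80%.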

Compound 4, a percentage reported as inhibition, at one concentration (the size of the read-out at that concentration, not a potency): 86.4%
For compound 4 the middle estimate is 20.4 percentage points below the measured one; measured number above the stated range.
By their numbers in this assay, from the lowest: compounds 3 and 1 (each within the scatter of the next); then compounds 2 and 4 (each within the scatter of the next).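

In this assay, a directly attached aromatic ring on this amine nitrogen does not tie the series to the lower values: 2-fluorophenyl in place of pyrimidin-2-yl gives a number 21.6 percentage points higher from compound 3 to compound 4 (beyond the scatter). The (pyridinyl)methyl groups respond differently to the same replacement, with a number 21.2 percentage points higher from compound 1 to compound 4 (beyond the scatter) but only a number 7.1 percentage points higher from compound 2 to compound 4 (within the scatter), so compound 2 and compound 4 are not ordered. No supporting data accompany these results to explain the change.

The contributions of the fluorine and the carbon-only ring remain unseparated. An unsubstituted phenyl or a 2-chlorophenyl on this nitrogen would address that.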